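A few compounds are considered here, and "the series" means these few. Any claim that something is new, unique, unknown or untested is made for them only; others in the source may bear on it.

Measured so far in an assay on isolated protein for agonist activity at Bile acid receptor (Homo sapiens), read by AlphaScreen, with a stated time of 30 min; on this read-out lower numbers stand for smaller maximal responses and higher numbers for larger maximal responses:
compound 1, `Cc1ccccc1-n1nc(C)c2c1NC(=O)[C@H](C)S[C@@H]2c1ccc(-c2ccoc2)cc1`, gives 40%
compound 2, `Cc1ccc(-n2nc(C)c3c2NC(=O)[C@H](C)S[C@@H]3c2ccc(Oc3ccccc3)cc2)cc1`, gives 11%
compound 3, `Cc1nn(-c2ccccc2I)c2c1C(c1ccc(Oc3ccccc3)cc1)SC(C)C(=O)N2`, gives 130%

Compound 3 stands highest of the three on this assay. Its nearest neighbour on the numbers is compound 1, which lies far lower, beyond the scatter; compound 2 lies lower still, also beyond the scatter. No pair among these three differs in one place only, so none of these gaps can be tied to a single structural change.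

Compound 4, `Cc1nn(-c2ccccc2Cl)c2c1C(c1ccc(Oc3ccccc3)cc1)SC(C)C(=O)N2`, has not yet been measured in this assay. It differs from compound 3 by chloro in place of iodo on an aromatic carbon. The change sits on an aromatic carbon of a six-membered aromatic ring of carbon only, ortho to a large group; read one bond further out, 2-iodophenyl becomes 2-chlorophenyl.

For the measured compounds named here, with no measured step to lean on, the expectation rests on compound 3 alone, and the step from it is expected to be a modest decrease in this assay, perhaps not beyond the scatter: a number 30 percentage points lower from compound 3 to compound 4 (beyond the scatter). Compound 4 is therefore estimated to reach about 100%, within a range from 60% to 140%.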

Compound 4, largest response reached (reported as efficacy), in percent of the reference or control that the assay uses: 57%
Beside the measured number, compound 4's estimate is 43 percentage points above it; the measured number lies below the stated range.
By their numbers in this assay, from the lowest: compound 2; then compound 1; then compound 4; then compound 3.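

In this assay, for the compounds shown here, the exchange of iodo for chloro on an aromatic carbon ortho to a large group gives a number 73 percentage points lower from compound 3 to compound 4 (beyond the scatter), the first step in this set that can be tied to a single structural change. It shows that this position is not indifferent to which halogen it carries: the group that leaves and the group that enters each count one heavy atom, with no ring, no hydrogen-bond donors or acceptors and no net charge, yet the maximal response differs well beyond the scatter. No measurement at hand accounts for why these two halogens differ so widely.

As far as these compounds go, with only iodo and chloro to compare at this place, it remains open whether bromo would give a response near that of compound 3, near that of compound 4 or somewhere between them, and where fluoro, methoxy or nitrile would fall. A single step also leaves open whether the same exchange would have an effect of similar size if the rest of the molecule were changed, for instance with a benzyloxy group in place of the phenoxy group.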